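A few compounds are considered here, and "the series" means these few. Any claim that something is new, unique, unknown or untested is made for them only; others in the source may bear on it.

The compounds here were compared in a functional assay on OVCAR-8 cells (Homo sapiens); on this read-out lower numbers stand for stronger inhibition of growth and higher numbers for weaker inhibition of growth. Compound 1 `O=S(=O)(/C=C/c1ccc(F)cc1)Cc1ccc(Nc2ncnc3ccccc23)cc1` gives 2000 nM in this assay. Compound 2 `O=S(=O)(/C=C/c1ccc(Cl)cc1)Cc1ccc(Nc2ncnc3ccccc23)cc1` differs from compound 1 in a single spot. In this assay compound 2 reaches only a limit, > 100000 nM. The change between them, (fluoro in place of chloro on an aromatic carbon), therefore gives an at least 50-fold lower number from compound 2 to compound 1 (1.69 log units; beyond the scatter), though the true size of that step cannot be fixed because the limit of > 100000 nM in this assay, at which 2 of the 3 values shown sit, leaves the starting value open upward.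

Compound 3 `O=S(=O)(/C=C/c1ccc(F)cc1Cl)Cc1ccc(Nc2ncnc3cc(Cl)ccc23)cc1` carries a different core; the difference between the two cores of compound 2 and compound 3 is not broken down here. In this assay compound 3 also sits at a limit, > 100000 nM.

Compound 4 `O=S(=O)(/C=C/c1ccc(F)cc1F)Cc1ccc(Nc2ncnc3cc(Cl)ccc23)cc1` has not been measured. It differs from compound 3 by fluoro in place of chloro on an aromatic carbon. Among the measured compounds shown here, this is the same kind of change as the one from compound 2 to compound 1, but not the same: there the place was para to a large group, here it is ortho to a large group and meta to a fluoro group.

The step expected from compound 3 to compound 4 in this assay is an at least 5.0-fold lower number from compound 3 to compound 4 (0.69 log units; beyond the scatter). For the measured compounds named here, that expectation rests on an at least 50-fold lower number from compound 2 to compound 1 (1.69 log units; beyond the scatter), the only measured step of this kind, tempered by the differing surroundings of the change. For compound 4 in this assay the estimated value is 20000 nM, with a range from 2000 nM to 100000 nM.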

Compound 4, concentration for 50% growth inhibition: > 100000 nM
Compound 4: only a limit was reported; the forecaster's own chance of this, stated with the estimate: 40%; at least 5.0-fold (0.69 log units) between middle value and limit.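

No size can be read for the change from compound 3 to compound 4, because both compounds rest on the same limit of the read-out: the limit of > 100000 nM in this assay, at which 3 of the 4 values shown sit.

The compounds shown leave open whether going from 2-chloro-4-fluorophenyl to 2,4-difluorophenyl changes growth inhibition at all in this assay, and whether the large step between compound 2 and compound 1 has any counterpart on the core of compound 3.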